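Epimer of a methoxymethyl diarylmethane: expected cytotoxicity

The source may hold more compounds than are shown below. What is called first, only, known or untested is meant among the compounds shown, and "the series" means these compounds.

Compound 1 `COc1cc(C(c2ccc(O)c(OC)c2)[C@@H](C)C(C)C)ccc1O`: 19000 nM
Compound 2 `COC[C@@H](C)[C@@H](C)C(c1ccc(O)c(OC)c1)c1ccc(O)c(OC)c1`: > 100000 nM

In a functional assay on HeLa cells (Homo sapiens) for cytotoxicity, read by WST assay, with a stated time of 48 h (on this read-out higher numbers stand for weaker inhibition and lower numbers for stronger inhibition), compound 1 gives 19000 nM. For compound 2 this assay reports only a limit, > 100000 nM, at the limit of > 100000 nM in this assay, at which 1 of the 2 values shown sits. Among the measured compounds shown here, the one measured step, an at least 5.2-fold higher number from compound 1 to compound 2 (0.72 log units; beyond the scatter), changes the chain, not configuration, so it bears only loosely on compound 3 `COC[C@@H](C)[C@H](C)C(c1ccc(O)c(OC)c1)c1ccc(O)c(OC)c1`, which differs from compound 2 as the two compounds have the same atoms and bonds and differ only in configuration as drawn: 1 of 2 stereo elements differ; a stereocentre at a saturated chain carbon is drawn S in compound 2 and R in compound 3. For the measured compounds named here, no measured step involves a change of configuration alone. Compound 3 is therefore expected to sit near compound 2, with a number no higher from compound 2 to compound 3 (the limit leaves the size open) estimated as no change beyond the scatter. Compound 3 is estimated at 100000 nM, between 30000 nM and 300000 nM, most likely again as a limit.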

Compound 3, half-maximal inhibitory concentration: 58000 nM
Beside the measured number, compound 3's estimate is 1.7-fold (0.24 log units) above it; low and high end bracket the measured number.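

With a number on both sides, methoxy in place of hydrogen on a saturated chain carbon can now be sized in this assay: a 3.1-fold higher number from compound 1 to compound 3 (0.48 log units; beyond the scatter). Changing only the configuration at the saturated chain carbon gives an at least 1.7-fold lower number from compound 2 to compound 3 (0.23 log units; that floor lies within the scatter). This is a floor within the scatter, so it does not establish an effect of configuration, since compound 2 has only a limit: the limit of > 100000 nM in this assay, at which 1 of the 3 values shown sits.

Going by these compounds, how an amine or a carboxylic acid in place of the methoxy would read in this assay stays open. So does the effect of a longer chain.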